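A few compounds are considered here, and "the series" means these few. Any claim that something is new, unique, unknown or untested is made for them only; others in the source may bear on it.

Measured so far in a functional assay on HCT-116 cells (Homo sapiens) for cytotoxicity, read by MTT assay, with a stated time of 48 h; on this read-out higher numbers stand for weaker inhibition and lower numbers for stronger inhibition:
compound 1 `O=C(/C=C/c1ccc2c(c1)B(O)OC2)c1ccccc1`: 6100 nM
compound 2 `O=C(/C=C/c1ccc2c(c1)B(O)OC2)c1cccnc1`: 20500 nM
compound 3 `CSc1ccc(C(=O)/C=C/c2ccc3c(c2)B(O)OC3)cc1`: 10300 nM

Compound 3 holds the second highest of the three numbers. Its nearest neighbour is compound 1, the step of a 1.7-fold higher number from compound 1 to compound 3 (0.23 log units; within the scatter) being within the scatter; compound 2 is the furthest, and its number and that of compound 3 also lie within the scatter of each other.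

Compound 4 `O=C(/C=C/c1ccc2c(c1)B(O)OC2)c1ccc(O)cc1` differs from compound 3 by hydroxy in place of methylsulfanyl on an aromatic carbon. Only a 1.7-fold higher number from compound 1 to compound 3 (0.23 log units; within the scatter) touches this position, and it was within the scatter; a 3.4-fold higher number from compound 1 to compound 2 (0.53 log units; beyond the scatter) concerns the ring itself and is modest. Among the compounds with values here, no measured compound carries a hydroxy here, so the expectation for compound 4 is a step of a 1.3-fold lower number from compound 3 to compound 4 (0.11 log units; within the scatter) that stays within the scatter. Compound 4 is estimated at 8000 nM, with a range of 3000 nM to 22000 nM.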

Compound 4, half-maximal inhibitory concentration: 24100 nM
Compound 4: the middle estimate sits 3.0-fold (0.48 log units) below what was measured, and the stated range ends below it.
By their numbers in this assay, from the lowest: compounds 1, 3, 2 and 4 (each within the scatter of the next, the first and the last beyond it).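

In this assay, this aromatic carbon, para to a large group, now gives a step beyond the scatter: hydroxy in place of hydrogen (a 4.0-fold higher number from compound 1 to compound 4 (0.60 log units; beyond the scatter)) and hydroxy in place of methylsulfanyl (a 2.3-fold higher number from compound 3 to compound 4 (0.37 log units; beyond the scatter)), so the outcome here depends on the group carried. 4-Hydroxyphenyl and pyridin-3-yl on the carbonyl carbon remain within the scatter of each other (a 1.2-fold higher number from compound 2 to compound 4 (0.07 log units; within the scatter)). Nothing measured here accounts for the hydroxy result. From the compounds shown here alone, whether methoxy, an amine or a carboxylic acid on this carbon would track with hydroxy or with methylsulfanyl remains open.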